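Anilide variation at the amide nitrogen of the nitrobenzofurazan thioether

The source may report more compounds than this note shows. Statements on the series, on what has been measured and on what is new or still open speak of the compounds shown alone.

Compound 1 `O=C(CCC(=O)OCCCCCCSc1ccc([N+](=O)[O-])c2nonc12)Nc1ccccc1` gives 1960 nM in a functional assay on A549 cells (Homo sapiens) for inhibition, read by MTT assay, with a stated time of 72 h; a higher number here means a weaker inhibitor, a lower number a stronger inhibitor. Compound 2 `O=C(CCC(=O)OCCCCCCSc1ccc([N+](=O)[O-])c2nonc12)Nc1ccccc1Cl` gives 2750 nM, the second highest of the three numbers; compound 3 `O=C(CCC(=O)OCCCCCCSc1ccc([N+](=O)[O-])c2nonc12)Nc1ccc(F)cc1` gives 6300 nM. The measured steps are a 1.4-fold higher number from compound 1 to compound 2 (0.15 log units; within the scatter), a 3.2-fold higher number from compound 1 to compound 3 (0.51 log units; beyond the scatter) and a 2.3-fold higher number from compound 2 to compound 3 (0.36 log units; beyond the scatter).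

Compound 4 `COc1ccc(NC(=O)CCC(=O)OCCCCCCSc2ccc([N+](=O)[O-])c3nonc23)cc1` carries 4-methoxyphenyl in place of 2-chlorophenyl on an amide-type nitrogen. The step from compound 2 to compound 3, which also replaces 2-chlorophenyl at that nitrogen, and the step from compound 1 to compound 3 both raised the number modestly, beyond the scatter. A modest rise is therefore expected, a 1.6-fold higher number from compound 2 to compound 4 (0.21 log units; within the scatter). Compound 4 is estimated at 4500 nM, within 1800 nM to 11000 nM.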

Compound 4, half-maximal inhibitory concentration: 6480 nM
Estimate against measurement, compound 4: 1.4-fold (0.16 log units) below, within the range that was stated.
By their numbers in this assay, from the lowest: compounds 1 and 2 (each within the scatter of the next); then compounds 3 and 4 (each within the scatter of the next).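

In this assay, 4-methoxyphenyl on the amide-type nitrogen gives a 2.4-fold higher number from compound 2 to compound 4 (0.37 log units; beyond the scatter) and a 3.3-fold higher number from compound 1 to compound 4 (0.52 log units; beyond the scatter), so a second substituted anilide separates from compound 1 and compound 2. Methoxy in place of fluoro gives a 1.0-fold higher number from compound 3 to compound 4 (0.01 log units; within the scatter), so compound 3 and compound 4 cannot be told apart here, even though the entering group adds a hydrogen-bond acceptor. Nothing available explains this shared level.

As far as these compounds go, whether it extends to an amine, a carboxylic acid or a nitrile on the anilide ring stays open. From the compounds shown here alone, the effect of a longer chain in the linker is also open.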